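A few compounds are considered here, and "the series" means these few. Any claim that something is new, unique, unknown or untested is made for them only; others in the source may bear on it.

Measured so far:
compound 1 `O=C(CCCCCCc1ccccc1)c1nc(-c2ccccn2)no1` – 0.34 nM
compound 2 `O=C(CCCCCCc1ccccc1)c1nc(-c2cccs2)no1` – 1.6 nM

In an assay for inhibition of Fatty-acid amide hydrolase 1 (Rattus norvegicus), at pH 9.0 (a higher number here means a weaker inhibitor, a lower number a stronger inhibitor), compound 1 gives 0.34 nM, the lowest of the two numbers. Its nearest neighbour is compound 2, which in this assay gives 1.6 nM; the step is a 4.7-fold higher number from compound 1 to compound 2 (0.67 log units; beyond the scatter), the result of swapping one aromatic ring for another on the shared core.

Compound 3 `COC(=O)c1cccc(-c2noc(C(=O)CCCCCCc3ccccc3)n2)n1` keeps the ring of compound 1 and differs from it only by methoxycarbonyl in place of hydrogen on an aromatic carbon. Among the measured compounds shown here, no measured step covers this kind of change: the one step seen, from compound 1 to compound 2, exchanges the whole ring rather than adding a group to it, so it gives no direct guide. With the ring retained, a modest step in this assay is expected, its direction open, most likely a somewhat higher number.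

For compound 3 the estimated value in this assay is 0.8 nM, with a range from 0.15 nM to 5 nM. That estimate for compound 3 means an expected step of a 2.4-fold higher number from compound 1 to compound 3 (0.37 log units; beyond the scatter).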

Compound 3, inhibition constant: 3 nM
Beside the measured number, compound 3's estimate is 3.8-fold (0.57 log units) below it; the range from low to high includes it.
By their numbers in this assay, from the lowest: compound 1; then compounds 2 and 3 (each within the scatter of the next).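

Methoxycarbonyl in place of hydrogen, on the carbon next to the ring nitrogen and meta to a large group, gives an 8.8-fold higher number from compound 1 to compound 3 (0.95 log units; beyond the scatter) in this assay and so yields a weaker inhibitor. The earlier step exchanged one whole ring for another, whereas this one keeps the ring and shows that adding a group of 4 heavy atoms at this single carbon is enough to move the number beyond the scatter. Even so, compound 3 at 3 nM remains a strong inhibitor, so this position accepts the added group with a modest loss, though nothing measured here accounts for that loss.

On these data alone, whether the loss belongs to this particular group or to any substituent at this carbon remains open. A methyl group or a carboxylic acid at the same carbon, or methoxycarbonyl elsewhere on the ring, would help separate those two readings.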